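A Methoxy Group Added to the Lowest Inhibitor

A few compounds are considered here, and "the series" means these few. Any claim that something is new, unique, unknown or untested is made for them only; others in the source may bear on it.

Of the compounds shown here, three that share one core have been measured in an assay on isolated protein for inhibition of beta-glucuronidase (Bos taurus), read by spectrophotometry, with a stated time of 30 min; on this read-out higher numbers stand for weaker inhibition and lower numbers for stronger inhibition. Compound 1 `Cc1ccc(Nc2nnc(-c3ccccc3Cl)s2)cc1` gives 16700 nM. Compound 2 `Clc1ccc(Nc2nnc(-c3ccccc3)s2)cc1Cl` gives 6280 nM. Compound 3 `Cc1ccc(Nc2nnc(-c3ccc(C)cc3C)s2)cc1` gives 34300 nM. Compound 2 stands lowest of the three numbers, and its gap to compound 1 as well as its gap to compound 3 lies beyond the usual scatter of repeated measurements, so compound 2 is the strongest inhibitor of the measured set.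

Compound 4 `COc1ccc(-c2nnc(Nc3ccc(Cl)c(Cl)c3)s2)cc1` is the one still to be measured. It differs from compound 2 in one place: methoxy in place of hydrogen on an aromatic carbon, on an aromatic carbon of a six-membered aromatic ring of carbon only, para to a large group. Among the measured compounds shown here, no pair of measured compounds shows what a methoxy group does at that place, so the direction of this step cannot be read from the numbers at hand. The expectation is a small step, most likely within the scatter, with a slight lean toward a lower number. The expected step in this assay is a 1.3-fold lower number from compound 2 to compound 4 (0.10 log units; within the scatter). Compound 4 is therefore estimated at 5000 nM, within a range from 2000 nM to 15000 nM.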

Compound 4, half-maximal inhibitory concentration: 4160 nM
Compound 4: the middle estimate sits 1.2-fold (0.08 log units) above what was measured, within the range that was stated.
By their numbers in this assay, from the lowest: compounds 4 and 2 (each within the scatter of the next); then compound 1; then compound 3.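

In this assay, among the compounds shown here, methoxy in place of hydrogen on this aromatic carbon, para to a large group, gives a 1.5-fold lower number from compound 2 to compound 4 (0.18 log units; within the scatter), the first measured example of this change at this place. The step lies within the scatter, so the two compounds cannot be told apart, and this position, which held only hydrogen in the earlier comparison compound, can carry a methoxy group with no loss of inhibition beyond the scatter. Nothing measured here bears on why the number stays so close when the group is added, so the result stands as an observation without an explanation.

The compounds shown do not say whether other groups at this same place, such as a hydroxyl, an amine, a carboxylic acid or a longer chain like ethoxy, would also leave the number within the scatter, or would move it clearly in either direction. They also leave open whether methoxy would give a similarly small step on a compound that carries different groups on its other ring, such as compound 1.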